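A few compounds are considered here, and "the series" means these few. Any claim that something is new, unique, unknown or untested is made for them only; others in the source may bear on it.

Of the compounds shown here, three sharing one core have been tested in a functional assay on MCF7 cells (Homo sapiens) for cytotoxicity, read by MTT assay, with a stated time of 24 h, tested at 32 ug/mL; on this read-out lower numbers stand for a weaker effect and higher numbers for a stronger effect at the one concentration tested. Compound 1 `CN1CCN(CC(=O)Nc2ccc(-c3nc(-c4ccccc4)c(-c4ccccc4)n3C)cc2)CC1` gives 46.2%. Compound 2 `CN(C)/C=C/N1CCN(CC(=O)Nc2ccc(-c3nc(-c4ccccc4)c(-c4ccccc4)n3C)cc2)CC1` gives 25.8%. Compound 3 `Cn1c(-c2ccc(NC(=O)CN3CCN(c4ccccc4)CC3)cc2)nc(-c2ccccc2)c1-c1ccccc1` gives 63.6%, the highest of the three, since a number 17.4 percentage points higher from compound 1 to compound 3 (beyond the scatter) and a number 37.8 percentage points higher from compound 2 to compound 3 (beyond the scatter) both lie beyond the scatter. Compound 4 `Cn1c(-c2ccc(NC(=O)CN3CCN(Cc4ccccc4)CC3)cc2)nc(-c2ccccc2)c1-c1ccccc1` differs from compound 3 by benzyl in place of phenyl on an amine nitrogen in a ring. Among the measured compounds shown here, the steps that bear on this are the two leading to compound 3, both gains, the phenyl on that ring nitrogen outperforming methyl and 2-(dimethylamino)ethenyl. Benzyl keeps the aromatic ring of phenyl, so compound 4 is expected to stay near compound 3, with a step of a number 8.6 percentage points lower from compound 3 to compound 4 (within the scatter) or none beyond the scatter. Compound 4 is therefore estimated at 55%, within 35% to 75%.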

Compound 4, a percentage reported as activity, at one concentration (the size of the read-out at that concentration, not a potency): 33.6%
Compound 4: middle estimate off by 21.4 percentage points, on the high side, and the stated range ends above it.
By their numbers in this assay, from the lowest: compounds 2 and 4 (each within the scatter of the next); then compound 1; then compound 3.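

At this ring nitrogen, keeping one six-membered aromatic ring of carbon only does not preserve the result in this assay: benzyl in place of phenyl gives (a number 30 percentage points lower from compound 3 to compound 4 (beyond the scatter)). Benzyl also stands short of methyl (a number 12.6 percentage points lower from compound 1 to compound 4 (beyond the scatter)) and is not separated from 2-(dimethylamino)ethenyl (a number 7.8 percentage points higher from compound 2 to compound 4 (within the scatter)), so the gain belongs to phenyl itself among these groups. Nothing measured here explains this drop. On these data alone, it remains open whether a 2-phenylethyl group, or a phenyl carrying a methoxy group or a chlorine, would match compound 3 .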